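The source may hold more compounds than are shown below. What is called first, only, known or untested is meant among the compounds shown, and "the series" means these compounds.

Compound 1 `CC(C)(NC(=O)c1ccc([N+](=O)[O-])o1)c1ccc(OC(F)(F)F)cc1`: 70000 nM
Compound 2 `CC(C)(NC(=O)c1ccc([N+](=O)[O-])o1)c1ccc(C(F)(F)F)cc1`: > 150000 nM, a limit
Compound 3 `CC(C)(NC(=O)c1ccc([N+](=O)[O-])o1)c1ccc(COc2ccc(OC(F)(F)F)cc2)cc1`: 6700 nM

All three were tested in an ADME assay on Vero cells (Chlorocebus sabaeus) for cytotoxicity, read by MTT assay, with a stated time of 48 h; a lower number here means that less compound is tolerated, a higher number that more compound is tolerated. Compound 1 gives 70000 nM in this assay. For compound 2 this assay reports only a limit, > 150000 nM, and at that limit (the limit of > 150000 nM in this assay, at which 1 of the 3 values shown sits). The change from compound 1 to compound 2 is trifluoromethyl in place of trifluoromethoxy on an aromatic carbon, and it made a step of an at least 2.1-fold higher number from compound 1 to compound 2 (0.33 log units; beyond the scatter), so compound 2 is tolerated at least modestly better than compound 1.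

Compound 3 gives 6700 nM in this assay, the lowest of the two numbers; it differs from compound 1 by a large part of the molecule, and the difference between the two cores is not broken down here.

Compound 4 `CC(C)(NC(=O)c1ccc([N+](=O)[O-])o1)c1ccc(COc2ccc(C(F)(F)F)cc2)cc1` has not yet been measured. It differs from compound 3 by trifluoromethyl in place of trifluoromethoxy on an aromatic carbon. This is the same change as from compound 1 to compound 2, at the same kind of place on the ring. Because the earlier step was an at least 2.1-fold higher number from compound 1 to compound 2 (0.33 log units; beyond the scatter), a move toward a higher number is expected here as well. The expected step is a 2.2-fold higher number from compound 3 to compound 4 (0.35 log units; beyond the scatter), an estimate that rests on an at least 2.1-fold higher number from compound 1 to compound 2 (0.33 log units; beyond the scatter). Compound 4 is expected to give about 15000 nM in this assay, with a likely range from 6000 nM to 40000 nM.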

Compound 4, half-maximal cytotoxic concentration: 7000 nM
The estimate for compound 4 lay 2.1-fold (0.33 log units) above the measured number; the measured number falls inside the stated range.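

On the core of compound 3, putting trifluoromethyl in place of trifluoromethoxy gave a 1.0-fold higher number from compound 3 to compound 4 (0.02 log units; within the scatter) in this assay, so on this core the swap produced no difference that can be told apart from the ordinary spread of repeated measurements. Set beside the same swap on the core of compound 1, the two results read as follows: the same change on two cores in this assay, an at least 2.1-fold higher number (0.33 log units; beyond the scatter) from compound 1 to compound 2 and a 1.0-fold higher number (0.02 log units; within the scatter) from compound 3 to compound 4; the limit leaves it open whether they differ Thus the clear step seen on the first core did not reappear on the second, but this does not show that the swap truly acts differently on the two cores, as the true size of the first step remains unknown and a single pair on each core is too little to set a rule for the series.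

The compounds shown leave open how other groups in the same place, such as a nitrile, a carboxylic acid or an amine, would compare with trifluoromethyl and trifluoromethoxy in this assay. They also leave open whether the same swap on a third core would follow the first result, the second, or neither.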